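What a side-chain swap may do to compound 1

The compounds below may be only part of what the source reports. "The series", "measured", "known", "first", "only" and "open" are said of these compounds alone.

In a physicochemical assay for lipophilicity, read by HPLC, at pH 7.5 (a lower number here means a more polar compound, a higher number a more lipophilic compound), compound 1 (`CCOc1ccccc1-c1ccc(-c2nc3cnccc3c(NC(C)C(=O)O)c2C#N)cc1`) gives 2.1 as the lowest of three numbers, beyond the scatter from both others. Compound 4 (`CCOc1ccccc1-c1ccc(-c2nc3cnccc3c(C[C@H](C)C(N)=O)c2C#N)cc1`) differs from it through 2-carbamoylpropyl in place of (1-carboxyethyl)amino on an aromatic carbon and nothing else. Going by the values given here, no measured step makes this swap. The only one available, a number 0.30 log units lower from compound 2 to compound 3 (within the scatter) within the scatter, lies elsewhere on the molecule and says little here. The better guide is that compound 4 gains a carbamoyl group also carried by compound 2 (`CC[C@@H](Nc1c(C#N)c(-c2ccc(-c3cccc(C)c3)cc2)nc2cnccc12)C(N)=O`) at 3 and by compound 3 (`CC[C@@H](Nc1c(C#N)c(-c2ccc(-c3ccc(OC)cc3)cc2)nc2cnccc12)C(N)=O`) at 2.7 in the same measurement. A rise is therefore expected, with a number 0.80 log units higher from compound 1 to compound 4 (beyond the scatter) as the estimated step beyond the scatter. The estimate for compound 4 is 2.9 within an expected range from 2.4 to 3.4 on this scale.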

Compound 4, distribution coefficient: 3
Compound 4: middle estimate off by 0.10 log units, on the low side; measured number inside the range.
By their numbers in this assay, from the lowest: compound 1; then compounds 3, 2 and 4 (each within the scatter of the next).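

In this assay, going by these compounds alone, on this aromatic carbon ortho to a cyano group, putting 2-carbamoylpropyl in place of (1-carboxyethyl)amino gives a number 0.90 log units higher from compound 1 to compound 4 (beyond the scatter), the first step at this position that clears the scatter. The swap changes the linking atom and the end of the chain together, so the step belongs to the whole change and not to either part. Nothing measured here accounts for the size of this step.

The compounds shown leave open how far each part contributes. They also leave open what a simple amine or a longer chain would do at this position.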